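This account rests on a few compounds, and the source may have more. Where it says the series, first, only, none or still open, it means among the compounds named here.

Measured so far in an assay on isolated protein for displacement of a labelled ligand from melanin-concentrating hormone receptor 1 (Homo sapiens); on this read-out lower numbers stand for stronger inhibition and higher numbers for weaker inhibition:
compound 1, `CCCc1cc(N)c2cc(NC(=O)/C=C/c3ccc(CC)cc3)ccc2n1` — 1.4 nM
compound 2, `CCCCc1ccc(/C=C/C(=O)Nc2ccc3nc(CCC)cc(N)c3c2)cc1` — 45 nM

Compound 2 stands at the higher of the two numbers; the nearest measured neighbour is compound 1, and the step of a 32-fold higher number from compound 1 to compound 2 (1.51 log units; beyond the scatter) is the only one in the set.

Compound 3, `CCCc1cc(N)c2cc(NC(=O)/C=C/c3ccc(Cl)cc3)ccc2n1`, has not yet been measured in this assay. It differs from compound 2 by chloro in place of butyl on an aromatic carbon. The aromatic carbon that carries the change is the same one at which compound 1 and compound 2 differ, so the step of a 32-fold higher number from compound 1 to compound 2 (1.51 log units; beyond the scatter) is the one that bears on it: there, lengthening the group on that carbon gave a large rise in the number. Compound 3 moves the other way, exchanging the butyl for a single-atom group. A large fall from compound 2 is therefore expected, a 15-fold lower number from compound 2 to compound 3 (1.18 log units; beyond the scatter), bringing the number back toward that of compound 1; how far beyond the level of compound 1 a chloro may reach is not settled by the two compounds measured, so the range is kept wide. For compound 3 the estimate in this assay is 3 nM, between 0.8 nM and 12 nM.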

Compound 3, half-maximal inhibitory concentration: 6 nM
Beside the measured number, compound 3's estimate is 2.0-fold (0.30 log units) below it, within the range that was stated.
By their numbers in this assay, from the lowest: compound 1; then compound 3; then compound 2.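

In this assay, chloro in place of butyl on the aromatic carbon para to a large group recovers much of the rise seen with the longer chain, giving a 7.5-fold lower number from compound 2 to compound 3 (0.88 log units; beyond the scatter). This carbon therefore accepts a single chlorine atom as well as a carbon chain, and the number stays in the low range without ethyl. The recovery is only partial, however, with a 4.3-fold higher number from compound 1 to compound 3 (0.63 log units; beyond the scatter): the number does not simply fall as the group shrinks, since chloro, the group with the fewest heavy atoms, goes against that trend and ethyl keeps the lowest number of the three compounds. Nothing at hand bears on the cause of these steps.

Still open, from the compounds shown here alone, is how the number changes along the chain from ethyl to butyl, which propyl at this carbon would help to locate, and whether a methyl or a methoxy group would reach the level of ethyl. Also open, going by these compounds, is whether other halogens, such as fluoro or bromo, would follow chloro, and whether these steps hold when the propyl chain on the core is changed.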